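Adding One Methyl to Compound 2

This account rests on a few compounds, and the source may have more. Where it says the series, first, only, none or still open, it means among the compounds named here.

Three related compounds have been measured in a functional assay on SK-MEL-2 cells (Homo sapiens) for cytotoxicity; a higher number here means a weaker inhibitor, a lower number a stronger inhibitor. Compound 1 (`Cc1ccc(-c2cc3ccccc3c(O)n2)cc1`) gives 5010 nM, compound 2 (`Cc1ccc2c(O)nc(-c3ccccc3)cc2c1`) gives 1580 nM and compound 3 (`Cc1ccc2c(O)nc(-c3ccccc3C)cc2c1`) gives 2630 nM. Compound 2 therefore has a clearly lower number than compound 1, which marks it as the stronger inhibitor of that pair, while compound 2 and compound 3 lie within the scatter of each other.

The next compound to consider is compound 4 (`Cc1ccc(-c2cc3cc(C)ccc3c(O)n2)cc1`). It is reached from compound 2 by one structural change: methyl in place of hydrogen on an aromatic carbon. This is a methyl in place of hydrogen on an aromatic carbon, on a six-membered aromatic ring of carbon only, para to a large group.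

Within the data shown here, only one measured step bears directly on this change. Compound 3 also arises from compound 2 by a methyl in place of hydrogen on an aromatic carbon, and that step is a 1.7-fold higher number from compound 2 to compound 3 (0.22 log units; within the scatter). A single step is thin evidence, but it points to a small move towards a higher number in this assay, and none beyond the scatter. The expected change is a 1.6-fold higher number from compound 2 to compound 4 (0.20 log units; within the scatter). For compound 4 the estimated value is 2500 nM, with an expected range of 1200 nM to 5200 nM.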

Compound 4, half-maximal inhibitory concentration: 7760 nM
The estimate for compound 4 lay 3.1-fold (0.49 log units) below the measured number; the measured number lies above the stated range.
By their numbers in this assay, from the lowest: compounds 2, 3, 1 and 4 (each within the scatter of the next, the first and the last beyond it).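

In this assay, among these compounds, a methyl para to a large group on compound 2 is the first methyl in place of hydrogen on an aromatic carbon to produce a step beyond the scatter: a 4.9-fold higher number from compound 2 to compound 4 (0.69 log units; beyond the scatter). Compound 4 can also be reached by this kind of change from the other side, and that route gives a 1.5-fold higher number from compound 1 to compound 4 (0.19 log units; within the scatter), which stays within the scatter, so the size of the step depends on which methyl is added and to which compound. The two smaller steps agree with each other, leaving the step from compound 2 as the one that goes against them: the same change on two cores in this assay, a 1.7-fold higher number (0.22 log units; within the scatter) from compound 2 to compound 3 and a 1.5-fold higher number (0.19 log units; within the scatter) from compound 1 to compound 4, 1.1-fold (0.03 log units) apart, within the scatter of two such steps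

From the compounds shown here alone, whether a methoxy group, a chlorine atom or a longer chain at this position, para to a large group, would give a step of similar size remains open, as does whether the higher number follows from the size of the group at all. The compounds shown also cannot tell why this methyl gives a larger step on compound 2 than the other two methyl changes do on their compounds.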